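From a nitro chalcone amide to a dimethoxy analogue

The source may hold more compounds than are shown below. What is called first, only, known or untested is meant among the compounds shown, and "the series" means these compounds.

Compound 1, `COC(=O)c1cc(-c2cccc(NC(=O)c3ccc(/C=C/C(=O)c4ccccc4C)cc3)c2)on1`: > 25 ug/mL
Compound 2, `COC(=O)c1cc(-c2cccc(NC(=O)c3ccc(/C=C/C(=O)c4ccc(C)c([N+](=O)[O-])c4)cc3)c2)on1`: > 80 ug/mL

In an ADME assay on Vero cells (Chlorocebus sabaeus) for cytotoxicity, read by MTT assay, with a stated time of 72 h (on this read-out lower numbers stand for higher toxicity in this test and higher numbers for lower toxicity in this test), compound 1 gives > 25 ug/mL, a limit of the assay rather than a number. Compound 2 gives > 80 ug/mL in this assay, again a limit. The step that the two limits leave unreadable from compound 1 to compound 2 cannot be read, because the limit of > 25 ug/mL in this assay, at which 1 of the 2 values shown sits, and the limit of > 80 ug/mL in this assay, at which 1 of the 2 values shown sits, are both limits. Compound 2 stands at the limit of the limit of > 80 ug/mL in this assay, at which 1 of the 2 values shown sits, the higher of the two limits shown.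

Compound 3, `COC(=O)c1cc(-c2cccc(NC(=O)c3ccc(/C=C/C(=O)c4ccc(OC)cc4OC)cc3)c2)on1`, differs from compound 2 by 2,4-dimethoxyphenyl in place of 4-methyl-3-nitrophenyl on a carbonyl carbon. Among the compounds with values here, no measured step bears on this change, so no shift beyond the scatter is expected in this assay. The expected step is an at least 1.3-fold lower number from compound 2 to compound 3 (0.12 log units; that floor lies within the scatter). Compound 3 is estimated at 60 ug/mL, with a range from 20 ug/mL to 150 ug/mL.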

Compound 3, half-maximal cytotoxic concentration: > 50 ug/mL
Compound 3 ended at the assay's limit; the forecaster's own chance of this, stated with the estimate: 65%; the middle value lies beyond the limit too.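

In this assay compound 3 gives > 50 ug/mL, which is a limit and not a number. No step among compound 1, compound 2 and compound 3 can be read, since each value is a limit: the limit of > 50 ug/mL in this assay, at which 1 of the 3 values shown sits.

As far as these compounds go, what remains open is where each of the three compounds would fall as an actual number on this read-out.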